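The source may hold more compounds than are shown below. What is called first, only, known or untested is meant among the compounds shown, and "the series" means these compounds.

Compound 1 `CCc1ccc(SCc2ccc(/C=C/C(=O)Nc3ccccc3N)cc2)cc1` gives 68.6%
Compound 2 `Cc1ccc(SCc2ccc(C(=O)Nc3ccccc3N)cc2)cc1` gives 78.3%

In a functional assay on A549 cells (Homo sapiens) for inhibition, read by CCK-8 assay, with a stated time of 72 h, tested at 8 uM (a higher number here means more inhibition of growth at the concentration tested, a lower number less inhibition of growth), compound 2 stands level with compound 1, as the gap between their two numbers lies within the scatter. Compound 3 `Cc1cc(C)cc(SCc2ccc(C(=O)Nc3ccccc3N)cc2)c1` has 3,5-dimethylphenyl in place of 4-methylphenyl on a sulfur and is otherwise the same as compound 2. For the measured compounds named here, no step between measured compounds is available to show the size of such a change, so the estimated a number 3.3 percentage points lower from compound 2 to compound 3 (within the scatter) in this assay is expected to stay within the scatter, with no firm direction. For compound 3 the expected value is 75% with an estimated range from 60% to 88% in this measurement.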

Compound 3, percent growth inhibition at one concentration: 78.5%
For compound 3 the middle estimate is 3.5 percentage points below the measured one; measured number inside the range.
By their numbers in this assay, from the lowest: compounds 1, 2 and 3 (each within the scatter of the next).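

In this assay, replacing 4-methylphenyl with 3,5-dimethylphenyl on a sulfur gives a number 0.2 percentage points higher from compound 2 to compound 3 (within the scatter). This first step at this position therefore shows that one added carbon and a different placement of the methyl groups leave growth inhibition unchanged within the scatter. Nothing available explains why the two groups read alike.

Still open, from the compounds shown here alone, is whether the reading would hold with an amine or a carboxylic acid on this ring, or with a longer chain in place of the methyl groups. One step at a single concentration cannot settle how far this holds.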